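The source may report more compounds than this note shows. Statements on the series, on what has been measured and on what is new or still open speak of the compounds shown alone.

Compound 1 `N#CC1=C(N)Oc2c(N)cc3nc4ccccc4nc3c2C12C(=O)N(Cc1cnnn1-c1ccc(F)c(Cl)c1)c1ccccc12`: in a functional assay on HCT-116 cells (Homo sapiens) for antiproliferative activity, read by MTT assay, with a stated time of 48 h (on this read-out lower numbers stand for stronger inhibition and higher numbers for weaker inhibition), compound 1 gives > 50000 nM, which is a limit of the assay rather than a number.
Compound 2 `N#CC1=C(N)Oc2c(N)cc3nc4ccccc4nc3c2C12C(=O)N(Cc1cnnn1-c1ccc(Cl)cc1[N+](=O)[O-])c1ccccc12`: in this assay compound 2 gives 28700 nM.

Compound 2 thus holds the only number shown in this assay; the other value is a limit (the limit of > 50000 nM in this assay, at which 1 of the 2 values shown sits). Compound 3 `COc1cc(-n2nncc2CN2C(=O)C3(C(C#N)=C(N)Oc4c(N)cc5nc6ccccc6nc5c43)c3ccccc32)c(OC)cc1Cl` differs from compound 2 by 4-chloro-2,5-dimethoxyphenyl in place of 4-chloro-2-nitrophenyl on an aromatic nitrogen. Among the measured compounds shown here, the one measured step on this aromatic nitrogen, an at least 1.7-fold lower number from compound 1 to compound 2 (0.24 log units; that floor lies within the scatter), lies within the scatter and offers little guidance on the size or direction of a further change of the aryl group. The expected step in this assay is therefore small, a 1.2-fold higher number from compound 2 to compound 3 (0.09 log units; within the scatter). Compound 3 is expected to give 35000 nM, between 12000 nM and 100000 nM.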

Compound 3, half-maximal inhibitory concentration: > 50000 nM
Compound 3: only a limit was reported (the forecaster's own chance of this, stated with the estimate: 45%); at least 1.4-fold (0.15 log units) between middle value and limit.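

With 4-chloro-2,5-dimethoxyphenyl in place of 4-chloro-2-nitrophenyl on this aromatic nitrogen, this assay shows an at least 1.7-fold higher number from compound 2 to compound 3 (0.24 log units; that floor lies within the scatter). The result for compound 3 is a limit of the assay and not a number, as is that for compound 1, so the step between these two cannot be read. Compound 2 thus remains the only compound with a number, and a second aryl change has ended at the limit: the limit of > 50000 nM in this assay, at which 2 of the 3 values shown sit.

From the compounds shown here alone, what a plain phenyl, or an amine on this phenyl ring, would give at this nitrogen stays open.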